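Swapping 2-fluorobenzyl for 4-bromobenzyl on a shared core

The source may report more compounds than this note shows. Statements on the series, on what has been measured and on what is new or still open speak of the compounds shown alone.

Measured so far in a functional assay on SW 1116 cells (Homo sapiens) for antiproliferative activity, read by MTT assay, with a stated time of 24 h; a lower number here means a stronger inhibitor, a higher number a weaker inhibitor:
- compound 1 `COc1cccc(CSc2nnc(-c3ccc4c(c3)OCCO4)n2-c2ccccc2)c1` gives 10100 nM
- compound 2 `Fc1ccccc1CSc1nnc(-c2ccc3c(c2)OCCO3)n1-c1ccccc1` gives 13600 nM

Among the compounds with values here, only two numbers exist, and compound 2 cannot be told apart from compound 1. Within the data shown here, the one measured step is a 1.3-fold higher number from compound 1 to compound 2 (0.13 log units; within the scatter) and it came from putting 2-fluorophenyl in place of 3-methoxyphenyl on a saturated chain carbon bound to a sulfur.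

Compound 3 `Brc1ccc(CSc2nnc(-c3ccc4c(c3)OCCO4)n2-c2ccccc2)cc1` has not yet been measured. Among the measured compounds shown here, it keeps the shared core of compound 2 and carries 4-bromophenyl in place of 2-fluorophenyl at that same place 4-bromophenyl in place of 2-fluorophenyl on a saturated chain carbon bound to a sulfur and no measured compound has this group yet.

For the measured compounds named here, the single step from compound 1 to compound 2 is the only guide, and it stayed within the scatter. A step beyond the scatter is therefore not expected in this assay for this new change. The expected step is a 1.1-fold lower number from compound 2 to compound 3 (0.05 log units; within the scatter) and this is an estimate resting on very little. For compound 3 the estimated value is 12000 nM with an expected range from 5000 nM to 28000 nM in this assay.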

Compound 3, half-maximal inhibitory concentration: 5810 nM
Compound 3: the middle estimate sits 2.1-fold (0.32 log units) above what was measured, and the stated range covers the measured number.
By their numbers in this assay, from the lowest: compounds 3, 1 and 2 (each within the scatter of the next, the first and the last beyond it).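

Within the data shown here, this position, on a saturated chain carbon bound to a sulfur, can shift the number in this assay beyond the usual scatter, though only modestly: 4-bromophenyl in place of 2-fluorophenyl gives a 2.3-fold lower number from compound 2 to compound 3 (0.37 log units; beyond the scatter) and is the first step here to clear it. Set against 3-methoxyphenyl, the same 4-bromophenyl group gives a 1.7-fold lower number from compound 1 to compound 3 (0.24 log units; within the scatter) so compound 3 stands apart from compound 2 but cannot be told apart from compound 1, and a single substituted ring does not decide the outcome on its own. No measurement is available to explain why this swap moves the number.

The change replaces fluorine with bromine and also alters the ring position named in each group, so these compounds cannot separate those two changes; 4-fluorophenyl and 2-bromophenyl would pull them apart. Also open, on these data alone, is how an unsubstituted phenyl, a ring bearing a carboxylic acid or an amine, or a longer chain in place of the benzyl group would behave at this place.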